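Aryl variation on the shared core: towards compound 4

This account rests on a few compounds, and the source may have more. Where it says the series, first, only, none or still open, it means among the compounds named here.

Measured so far:
compound 1 `N#CC1=C(N)N(c2ccc(S(N)(=O)=O)cc2)C2=C(C(=O)CCC2)C1c1ccccc1` — 10%
compound 2 `Cc1ccc(C2C(C#N)=C(N)N(c3ccc(S(N)(=O)=O)cc3)C3=C2C(=O)CCC3)cc1` — 30%
compound 3 `COc1ccc(C2C(C#N)=C(N)N(c3ccc(S(N)(=O)=O)cc3)C3=C2C(=O)CCC3)cc1` — 30%

All three numbers come from a functional assay on Ehrlich cells (Mus musculus) for antiproliferative activity, read by trypan blue exclusion, with a stated time of 2 h, tested at 10 ug/mL; a lower number here means a weaker effect, a higher number a stronger effect of the compound at the concentration tested. Compound 2 stands level with compound 3 at the digits shown, the two together the highest of the three; its nearest neighbour is compound 3, with no change at the digits printed from compound 2 to compound 3 (within the scatter), and its furthest is compound 1, from which a number 20 percentage points higher from compound 1 to compound 2 (beyond the scatter). The parallel step a number 20 percentage points higher from compound 1 to compound 3 (beyond the scatter) is of the same size.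

Compound 4 `N#CC1=C(N)N(c2ccc(S(N)(=O)=O)cc2)C2=C(C(=O)CCC2)C1c1cccc([N+](=O)[O-])c1` is not yet measured. Its change from compound 2: 3-nitrophenyl in place of 4-methylphenyl on a saturated ring carbon. The measured steps cover methyl and methoxy in place of hydrogen on an aromatic carbon, both modest rises, and methoxy in place of methyl, no change beyond the scatter. None covers a nitro group, so the direction of this change is not known. A substituted aryl at this carbon is tolerated in compounds 2 and 3, and that is the only footing. For compound 4 the expected value in this assay is 30%, within 10% to 50%. The step this estimate means, no change at the digits printed from compound 2 to compound 4 (within the scatter), is expected to stay within the scatter.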

Compound 4, a percentage reported as activity, at one concentration (the size of the read-out at that concentration, not a potency): 42%
Beside the measured number, compound 4's estimate is 12 percentage points below it; the measured number falls inside the stated range.
By their numbers in this assay, from the lowest: compound 1; then compounds 2 and 3 (each within the scatter of the next); then compound 4.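

In this assay, the saturated ring carbon takes a 3-nitrophenyl group with a read-out beyond that of the 4-methylphenyl and 4-methoxyphenyl groups (a number 12 percentage points higher from compound 2 to compound 4 (beyond the scatter); a number 12 percentage points higher from compound 3 to compound 4 (beyond the scatter)), so the substituted aryl compounds are no longer level at this position. Against the unsubstituted phenyl of compound 1, nitro in place of hydrogen gives a large rise (a number 32 percentage points higher from compound 1 to compound 4 (beyond the scatter)), and all three substituted aryl groups shown now stand above compound 1. No measurement at hand accounts for this rise.

Compound 4 differs from compound 2 in both the group and its place on the phenyl ring, and the compounds shown do not separate these two changes. As far as these compounds go, whether an amine or a carboxylic acid on that phenyl ring would raise or lower the read-out stays open.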